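Chloro for Methoxy on a Weakly Cytotoxic Thiazoline Hydrazone

A few compounds are considered here, and "the series" means these few. Any claim that something is new, unique, unknown or untested is made for them only; others in the source may bear on it.

This account concerns three measured compounds and one that awaits measurement, all tested in a functional assay on HCT-116 cells (Homo sapiens) for cytotoxicity, read by sulforhodamine B assay, with a stated time of 48 h; on this read-out higher numbers stand for lower toxicity in this test and lower numbers for higher toxicity in this test. Compound 1, with the structure `COc1ccc(-c2cs/c(=N\NC(=O)c3ccc(O)cc3)n2-c2ccc(OC)cc2OC)cc1`, shows no number in this assay: its value of < 100000 nM is a limit of the assay. Compound 3, `Cc1ccc(-c2cs/c(=N\NC(=O)c3ccc(O)cc3)n2-c2c(C)cccc2C)cc1`, also sits at a limit, giving < 100000 nM in this assay. Compound 2, built on a different core, `O=C(c1ccc(O)cc1)n1nc(-c2c(Cl)cccc2Cl)sc1=S`, is the only one with a numerical result, giving 52500 nM in this assay. Compound 1 therefore stands where most of the series stands, at the limit, as the evidence the limit of < 100000 nM in this assay, at which 2 of the 3 values shown sit, shows, with only compound 2 reporting a number at all.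

Compound 4, `COc1ccc(-n2c(-c3ccc(Cl)cc3)cs/c2=N\NC(=O)c2ccc(O)cc2)c(OC)c1`, is compound 1 with the change (chloro in place of methoxy on an aromatic carbon), which read one bond further out is 4-methoxyphenyl to 4-chlorophenyl. For the measured compounds named here, no pair of measured compounds in this set differs in exactly one place, so no measured step guides the expectation. Given that compound 1 gives < 100000 nM in this assay, compound 4 is expected to remain close to that limit as well, with no step beyond the usual scatter. This corresponds to an expected step that the limit leaves unreadable from compound 1 to compound 4. Compound 4 is thus estimated at 90000 nM, within a range from 30000 nM to 200000 nM, most likely reported again only as a limit.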

Compound 4, concentration lethal to 50% of the cells: < 100000 nM
Compound 4: a limit, no number; the forecaster's own chance of this, stated with the estimate: 70%; the middle value is on the limit's open side.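

Compound 4, like compound 1, gives only a limit and no number, so no step between compound 1 and compound 4 can be read in this assay, and the result joins most of the set: the limit of < 100000 nM in this assay, at which 3 of the 4 values shown sit.

The compounds shown leave open whether chloro in place of methoxy on an aromatic carbon changes toxicity in this assay at all.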